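Three compounds level, a fourth awaits its number

This account rests on a few compounds, and the source may have more. Where it says the series, first, only, none or still open, it means among the compounds named here.

compound 1 `N#CC1=C(N)N2CCCNC2=C([N+](=O)[O-])C12c1ccccc1-c1nc3ccccc3nc12` gives 174000 nM
compound 2 `N#CC1=C(N)N2CCNC2=C([N+](=O)[O-])C12c1ccccc1-c1nc3ccc([N+](=O)[O-])cc3nc12` gives 174000 nM
compound 3 `Cc1cc2nc3c(nc2cc1C)C1(C(C#N)=C(N)N(Cc2ccccc2)C(NCc2ccccc2)=C1[N+](=O)[O-])c1ccccc1-3` gives 174000 nM

In an ADME assay on HepG2 cells (Homo sapiens) for cytotoxicity, read by MTT assay, with a stated time of 48 h (on this read-out lower numbers stand for stronger inhibition and higher numbers for weaker inhibition), compound 2 gives 174000 nM and so stands level with the other two compounds at the digits shown. Among the compounds with values here, compound 4 `N#CC1=C(N)N2CCNC2=C([N+](=O)[O-])C12c1ccccc1-c1nc3ccccc3nc12` has no measurement yet. The change from compound 2 to compound 4 is hydrogen in place of nitro on an aromatic carbon and the rest of the structure stays the same.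

Within the data shown here, no pair of measured compounds differs in one place only, so this change has no direct precedent. Compound 1 with 174000 nM and compound 3 with 174000 nM differ in structure from compound 2 yet show no change beyond the scatter. On that basis, no step beyond the scatter is expected in this assay in either direction. The expected outcome is no change at the digits printed from compound 2 to compound 4 (within the scatter) and this estimate leaves compound 4 level with the others. In this assay compound 4 is estimated at 174000 nM with an expected range from 110000 nM to 260000 nM on measurement.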

Compound 4, half-maximal inhibitory concentration: 194000 nM
Compound 4: the middle estimate sits 1.1-fold (0.05 log units) below what was measured; the measured number falls inside the stated range.
By their numbers in this assay, from the lowest: compounds 1, 2, 3 and 4 (each within the scatter of the next).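

In this assay, within the data shown here, the step of a 1.1-fold higher number from compound 2 to compound 4 (0.05 log units; within the scatter) is the first direct reading of a single change in this set: hydrogen in place of nitro on an aromatic carbon. It lies within the scatter, so at this position, on a six-membered aromatic ring of carbon only, the assay does not tell the nitro group from hydrogen on this shared core. Nothing available here offers an explanation for this result.

From the compounds shown here alone, whether an amine, a carboxylic acid or a chlorine atom on the same aromatic carbon would also stay within the scatter remains open. So does whether the same exchange would read alike on the core of compound 1 or of compound 3, since this one pair is the only reading of it.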